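Notes on a cytotoxicity series and one methoxy analogue

This account rests on a few compounds, and the source may have more. Where it says the series, first, only, none or still open, it means among the compounds named here.

compound 1 `CCCN1C(N)=NC(N)=NC12CCN(C(=O)C1CC1)CC2` gives > 100000 nM in an ADME assay on HeLa cells (Homo sapiens) for cytotoxicity, read by microscopy, with a stated time of 6 days (a lower number here means that less compound is tolerated, a higher number that more compound is tolerated), a limit of the assay.
compound 2 `CCCN1C(N)=NC(N)=NC12CCN(C(=O)c1c(C)noc1C)CC2` gives > 100000 nM in this assay, a limit of the assay.
compound 3 `CCCN1C(N)=NC(N)=NC12CCN(C(=O)NCCC(=O)OCC)CC2` gives > 100000 nM in this assay, a limit of the assay.

Compound 1 therefore stands at a limit and not at a number, and so do the two other measured compounds, as the limit of > 100000 nM in this assay, at which 3 of the 3 values shown sit, records. The changes among them all sit on the carbonyl carbon: a step that the two limits leave unreadable from compound 1 to compound 2, a step that the two limits leave unreadable from compound 1 to compound 3 and a step that the two limits leave unreadable from compound 2 to compound 3 are each unreadable between two limits, so no size and no direction can be taken from them.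

Compound 4 `COCCN1C(N)=NC(N)=NC12CCN(C(=O)C1CC1)CC2` is the next case. It differs from compound 1 by methoxy in place of methyl on a saturated chain carbon, two bonds along the chain from an amine nitrogen in a ring. Going by the values given here, none of the measured steps touches this chain; the only evidence that bears on it is that every change tried so far left the read-out at the limit (the limit of > 100000 nM in this assay, at which 3 of the 3 values shown sit). The expectation for the step from compound 1 to compound 4 in this assay is accordingly one of no step beyond the scatter, with the result most likely reported again as a limit rather than a number: a number no higher from compound 1 to compound 4 (the limit leaves the size open). The estimate for compound 4 in this assay is 100000 nM, expected to fall between 50000 nM and 200000 nM.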

Compound 4, minimum cytotoxic concentration: > 100000 nM
Compound 4: a limit, no number; the forecaster's own chance of this, stated with the estimate: 80%; the middle value lies on the limit itself.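

In this assay compound 4 gives > 100000 nM, a limit and not a number. Going by these compounds alone, compound 1 also stands at a limit, so no step in size or direction can be read between compound 1 and compound 4. The compounds shown leave open whether any of these changes alters the minimum cytotoxic concentration at all, with every read-out at one limit: the limit of > 100000 nM in this assay, at which 4 of the 4 values shown sit.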